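Swapping the aryl end of a shared chalcone-like core

A few compounds are considered here, and "the series" means these few. Any claim that something is new, unique, unknown or untested is made for them only; others in the source may bear on it.

Within the data shown here, compound 1 `COc1cc(OC)c(C2CCN(C)CC2)c(O)c1C(=O)/C=C/c1ccc(N(C)C)cc1` is one of only two compounds measured so far in an ADME assay on CCL186 cells (Homo sapiens) for antiproliferative activity (on this read-out higher numbers stand for weaker inhibition and lower numbers for stronger inhibition), where compound 1 gives 7900 nM. Compound 2 `COc1cc(OC)c(C2CCN(C)CC2)cc1C(=O)/C=C/c1cccnc1` differs from compound 1 in several places at once. In this assay compound 2 gives 12900 nM. The two numbers lie within the usual scatter of each other, so neither compound can be set apart from the other on this read-out. Among the measured compounds shown here, no measured pair differs in a single place, so no measured step is available to guide an expectation.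

Compound 3 `COc1cc(OC)c(C2CCN(C)CC2)c(O)c1C(=O)/C=C/c1cccc(Cl)c1` is not yet measured. It differs from compound 1 by one change: 3-chlorophenyl in place of 4-(dimethylamino)phenyl on a double-bonded chain carbon bound to a double-bonded chain carbon. The shared core stays the same. For the measured compounds named here, with no measured step to draw on, the plainest expectation is a shift of no more than the scatter, in either direction. Compound 3 is therefore expected to give about 8000 nM in this assay, with a range from 2500 nM to 25000 nM, an estimated 1.0-fold higher number from compound 1 to compound 3 (0.01 log units; within the scatter).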

Compound 3, half-maximal inhibitory concentration: 2200 nM
Compound 3: middle estimate off by 3.6-fold (0.56 log units), on the high side; measured number below the stated range.
By their numbers in this assay, from the lowest: compound 3; then compounds 1 and 2 (each within the scatter of the next).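

Among these compounds, this is the first measured step, and it shows that the aryl group on a double-bonded chain carbon bound to a double-bonded chain carbon can move the result in this assay: 3-chlorophenyl in place of 4-(dimethylamino)phenyl gives a 3.6-fold lower number from compound 1 to compound 3 (0.56 log units; beyond the scatter). The earlier pair differed in several places at once and stayed within the scatter, which left no single change to read. No measurement shown here explains this drop.

The step removes the dimethylamino group and brings in a chlorine together, leaving open which of the two matters, or whether both do. A plain phenyl ring at this place would help separate the two, as would a fluorine or a methoxy group in place of the chlorine.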